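This account rests on a few compounds, and the source may have more. Where it says the series, first, only, none or still open, it means among the compounds named here.

Measured compounds:
compound 1 `CC(C)Nc1nc(NCc2ccco2)c2ccccc2n1` – 17000 nM
compound 2 `OCCNc1nc(NCc2ccco2)c2ccccc2n1` – > 33000 nM

In an ADME assay on J774.A1 cells (Mus musculus) for cytotoxicity, read by MTT assay, with a stated time of 72 h (on this read-out lower numbers stand for an effect already at smaller amounts and higher numbers for an effect only at larger amounts of compound), compound 1 gives 17000 nM. Compound 2 reaches only a limit of this assay, > 33000 nM. Within the series compound 1 therefore holds the only number shown; the other value is a limit, as noted in the limit of > 33000 nM in this assay, at which 1 of the 2 values shown sits. Going by the values given here, the single measured step runs an at least 1.9-fold higher number from compound 1 to compound 2 (0.28 log units; that floor lies within the scatter), where 2-hydroxyethyl stands in place of isopropyl on a nitrogen on an aromatic ring; that step itself sits inside the scatter at its floor.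

Compound 3 `CSCCNc1nc(NC(C)C)nc2ccccc12` is not yet measured. It differs from compound 1 by (methylsulfanyl)methyl in place of furan-2-yl on a saturated chain carbon bound to a nitrogen on an aromatic ring. Among the compounds with values here, the measured step touches the isopropyl-bearing nitrogen and leaves the (furan-2-yl)methyl chain untouched, so no measured step bears directly on this change. Within the data shown here, with only one step available, and that one inside the scatter, no direction beyond the scatter can be read for the shift in this assay. Compound 3 is therefore expected near compound 1, with an estimated step of a 1.2-fold higher number from compound 1 to compound 3 (0.07 log units; within the scatter). The estimate for compound 3 is 20000 nM, with a range from 7000 nM to 50000 nM.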

Compound 3, half-maximal effective concentration: 20000 nM
Beside the measured number, compound 3's estimate shows no gap at the digits printed; low and high end bracket the measured number.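

In this assay, going by these compounds alone, the first reading at the (furan-2-yl)methyl side of the series is a 1.2-fold higher number from compound 1 to compound 3 (0.07 log units; within the scatter), with (methylsulfanyl)methyl in place of furan-2-yl on a saturated chain carbon bound to a nitrogen on an aromatic ring. The earlier step concerned only the isopropyl-bearing nitrogen, so this pair adds a new place: exchanging a five-membered aromatic ring for a group with no ring leaves the two numbers within the scatter of each other, and in this pair the ring is not needed for a number of this size. Nothing shown on these compounds accounts for this outcome.

Within the data shown here, still open is whether this place tolerates other groups equally, for example a phenyl ring, a longer chain, a terminal amine or a carboxylic acid, as the pair shows only one exchange. Also open, as far as these compounds go, is how 2-hydroxyethyl in place of isopropyl reads when 2-(methylsulfanyl)ethyl sits on the other nitrogen, as the two changes appear here only singly on the shared core.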